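Working notes on the shared core: the step to compound 3

The source may hold more compounds than are shown below. What is called first, only, known or untested is meant among the compounds shown, and "the series" means these compounds.

Compound 2 `CCOC(=O)CCCCCOc1cccc(CN(C(=O)c2ccc(-c3cccc(C(C)=O)c3)cc2)C(C)C)c1` carries an acetyl on an aromatic carbon of the shared core. In an ADME assay on BJ cells (Homo sapiens) for cytotoxicity, read by CellTiter-Glo and resazurin assay, with a stated time of 72 h (on this read-out lower numbers stand for an effect already at smaller amounts and higher numbers for an effect only at larger amounts of compound), compound 2 gives > 26000 nM, which is a limit of the assay and not a number. Compound 1 `CCOC(=O)CCCCCOc1cccc(CN(C(=O)c2ccc(-c3cccc(-c4ccccc4)c3)cc2)C(C)C)c1` differs from compound 2 only in carrying a phenyl in place of that acetyl. In this assay compound 1 gives > 26000 nM, also a limit. The step that the two limits leave unreadable from compound 1 to compound 2 is therefore unreadable, as the limit of > 26000 nM in this assay, at which 2 of the 2 values shown sit, sets out. Compound 3 `CCOC(=O)CCCCCOc1cccc(CN(C(=O)c2ccc(-c3cccc(OCc4ccccc4)c3)cc2)C(C)C)c1` has not yet been measured; it differs from compound 2 by benzyloxy in place of acetyl on an aromatic carbon. Within the data shown here, the only measured step concerns a change of the same group but gives no size. Since both known values sit at the limit, the estimated step is a step that the limit leaves unreadable from compound 2 to compound 3, none beyond the scatter. Compound 3 is expected at 30000 nM, in the range 15000 nM to 60000 nM, most likely again reported as a limit.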

Compound 3, half-maximal effective concentration: > 26000 nM
Compound 3: only a limit was reported (the forecaster's own chance of this, stated with the estimate: 85%); the middle value lies beyond the limit too.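

Compound 3, like compound 1 and compound 2, stands only as a limit, so no step among the three can be read: the limit of > 26000 nM in this assay, at which 3 of the 3 values shown sit.

The compounds shown leave open whether the phenyl, acetyl and benzyloxy groups differ at all in this assay.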